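Clearance notes: removing difluoromethyl from compound 1

The source may report more compounds than this note shows. Statements on the series, on what has been measured and on what is new or still open speak of the compounds shown alone.

Among the compounds with values here, in an in vitro ADME assay on microsomes from liver (Homo sapiens) for metabolic stability (a higher number here means faster removal of the compound, a lower number slower removal), compound 1 `Fc1ccccc1Cc1nc(-c2nc(C(F)F)n[nH]2)n2ccccc12` gives 62 mL.min-1.g-1 as the higher of the two actual numbers so far. Compound 2 `Fc1ccccc1Cc1nc(-c2nc(C(F)(F)F)n[nH]2)c2ccccn12` gives 20 mL.min-1.g-1 and sits lower by a gap beyond the scatter. Compound 3 `Cc1ncc(Cc2nc(-c3nc(C(F)(F)F)n[nH]3)n3cccc(F)c23)cn1` gives < 8 mL.min-1.g-1 and this is a limit of the assay. Compound 4 `Fc1ccccc1Cc1nc(-c2ncn[nH]2)n2ccccc12` carries hydrogen in place of difluoromethyl on an aromatic carbon and so has 1H-1,2,4-triazol-5-yl where compound 1 has 3-(difluoromethyl)-1H-1,2,4-triazol-5-yl. Within the data shown here, no measured pair isolates this change, so only a moderate fall in this assay is expected from compound 1 at 62 mL.min-1.g-1 and a result within the scatter remains possible. The expected step is a 2.1-fold lower number from compound 1 to compound 4 (0.32 log units; beyond the scatter) on this estimate. Compound 4 is estimated at 30 mL.min-1.g-1 with an expected range from 12 mL.min-1.g-1 to 70 mL.min-1.g-1 for now.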

Compound 4, intrinsic clearance in microsomes: 175 mL.min-1.g-1
Beside the measured number, compound 4's estimate is 5.8-fold (0.77 log units) below it; the whole stated range lies below it.
By their numbers in this assay, from the lowest: compound 2; then compound 1; then compound 4. At a limit, below all of these: compound 3.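

At this aromatic carbon, between two ring nitrogen atoms, the first single-place step reads a 2.8-fold higher number from compound 1 to compound 4 (0.45 log units; beyond the scatter) in this assay. The position therefore affects removal in this assay, and within this pair the difluoromethyl-bearing compound 1 is the slower removed. No measurement shown here bears on the reason for this step.

Still open, from the compounds shown here alone, is how a methyl group or an amine on the same carbon would stand against compound 1 and compound 4. Also open, going by these compounds, is whether the step carries over to the cores of compound 2 and compound 3.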